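Moving the Ethyl Group: From Compound 3 to Compound 4

A few compounds are considered here, and "the series" means these few. Any claim that something is new, unique, unknown or untested is made for them only; others in the source may bear on it.

In a functional assay on MCF7 cells (Homo sapiens) for antiproliferative activity, read by sulforhodamine B assay, with a stated time of 48 h (a lower number here means a stronger inhibitor, a higher number a weaker inhibitor), compound 1 `Cc1cccc(NS(=O)(=O)c2ccc(N3CCNC3=O)cc2)c1` gives 190 nM. Compound 2 `O=C1NCCN1c1ccc(S(=O)(=O)Nc2ccc(F)cc2)cc1` gives 690 nM, and compound 3 `CCc1ccc(NS(=O)(=O)c2ccc(N3CCNC3=O)cc2)cc1` gives 810 nM. Compound 3 thus has the highest of the three numbers, but it cannot be told apart from its nearest neighbour: a 1.2-fold higher number from compound 2 to compound 3 (0.07 log units; within the scatter) stays within the scatter. Its gap to the lowest number is clearer, at a 4.3-fold higher number from compound 1 to compound 3 (0.63 log units; beyond the scatter).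

Compound 4 `CCc1cccc(NS(=O)(=O)c2ccc(N3CCNC3=O)cc2)c1` contains the same atoms as compound 3, joined differently: 3-ethylphenyl in place of 4-ethylphenyl on a sulfonamide nitrogen. Among the measured compounds shown here, no measured pair isolates this exact swap. For the measured compounds named here, the closest evidence comes from the 3-methylphenyl group of compound 1, the only measured compound with a group named at the 3 position. Replacing it gave a 3.6-fold higher number from compound 1 to compound 2 (0.56 log units; beyond the scatter) and a 4.3-fold higher number from compound 1 to compound 3 (0.63 log units; beyond the scatter), both modest but beyond the scatter. The second of these steps also changes methyl to ethyl, so it cannot be credited to placement alone, and one compound is thin support for any trend.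

A modest drop in this assay is therefore expected, probably smaller than the full gap to compound 1. The estimated step is a 2.5-fold lower number from compound 3 to compound 4 (0.40 log units; beyond the scatter). Compound 4 is expected at 320 nM, with an estimated range from 130 nM to 800 nM.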

Compound 4, half-maximal inhibitory concentration: 130 nM
Estimate against measurement, compound 4: 2.5-fold (0.39 log units) above; low and high end bracket the measured number.
By their numbers in this assay, from the lowest: compounds 4 and 1 (each within the scatter of the next); then compounds 2 and 3 (each within the scatter of the next).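

In this assay, swapping 4-ethylphenyl for 3-ethylphenyl on the sulfonamide nitrogen keeps every atom and changes only where the ethyl group sits, yet it gives a 6.2-fold lower number from compound 3 to compound 4 (0.79 log units; beyond the scatter) and is beyond the scatter. Among the compounds shown here, this is the first pair to isolate placement, which the earlier steps could not do, and 3-ethylphenyl in place of 4-fluorophenyl likewise gives a 5.3-fold lower number from compound 2 to compound 4 (0.72 log units; beyond the scatter) and is beyond the scatter. The added carbon at the 3 position makes no clear difference, since the step of a 1.5-fold lower number from compound 1 to compound 4 (0.16 log units; within the scatter) stays within the scatter, so compound 1 and compound 4 cannot be told apart, and the methyl and ethyl groups at this position fit the assay about equally well.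

Still open, on these data alone, is whether a longer chain, as in 3-propylphenyl, or an amine, as in 3-aminophenyl, on the same sulfonamide nitrogen would keep numbers like these, or whether the tolerance at this position ends with ethyl. The compounds shown come with no measurement that accounts for the effect of moving the ethyl group.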